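Aryl variation on the tetrazole arm: expectation for compound 4

The source may hold more compounds than are shown below. What is called first, only, known or untested is meant among the compounds shown, and "the series" means these compounds.

Measured in an assay on HEK293 cells for activation of Kir3.1/Kir3.2 (Homo sapiens), read by thallium flux; a lower number here means that less compound is needed, a higher number that more compound is needed for the effect:
compound 1, `Cc1cc(NC(=O)Cn2nnc(-c3cccnc3)n2)n(C2CCCCC2)n1`, gives 1930 nM
compound 2, `Cc1cc(NC(=O)Cn2nnc(-c3cccc(Cl)c3)n2)n(C2CCCCC2)n1`, gives 300 nM
compound 3, `COc1cccc(-c2nnn(CC(=O)Nc3cc(C)nn3C3CCCCC3)n2)c1`, gives 117 nM

Compound 3 holds the lowest number of the three in this assay. The step of a 2.6-fold lower number from compound 2 to compound 3 (0.41 log units; beyond the scatter) separates it from compound 2, its nearest neighbour, and the step of a 16-fold lower number from compound 1 to compound 3 (1.22 log units; beyond the scatter) from compound 1, the furthest. The step of a 6.4-fold lower number from compound 1 to compound 2 (0.81 log units; beyond the scatter) shows that the chlorophenyl arm already stands well ahead of the pyridinyl arm.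

Compound 4, `Cc1cc(NC(=O)Cn2nnc(-c3ccc(Cl)c(C)c3)n2)n(C2CCCCC2)n1`, carries the change (4-chloro-3-methylphenyl in place of 3-methoxyphenyl on an aromatic carbon). Going by the values given here, no measured step covers this exact exchange. The step of a 2.6-fold lower number from compound 2 to compound 3 (0.41 log units; beyond the scatter) bears on it in reverse: going from methoxy back to chloro would be expected to raise the number by a modest amount. The chloro in compound 4 sits on a different ring carbon than in compound 2, and a methyl is added; neither point is covered by any measured pair. Taken together, a modest upward step is expected, about as large as the chloro-to-methoxy step but reversed, so that compound 4 is estimated near compound 2 rather than compound 3.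

For compound 4 the expected step is a 2.2-fold higher number from compound 3 to compound 4 (0.35 log units; beyond the scatter) in this assay. Compound 4 is estimated at 260 nM, with a range from 80 nM to 850 nM.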

Compound 4, half-maximal effective concentration: 712 nM
Beside the measured number, compound 4's estimate is 2.7-fold (0.44 log units) below it; measured number inside the range.
By their numbers in this assay, from the lowest: compound 3; then compound 2; then compound 4; then compound 1.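

At this position in this assay, a chlorine on the phenyl ring does not by itself fix the number: 4-chloro-3-methylphenyl in place of 3-chlorophenyl gives a 2.4-fold higher number from compound 2 to compound 4 (0.38 log units; beyond the scatter), so the substitution pattern counts as well as the kind of group. Against 3-methoxyphenyl, the same arm gives a 6.1-fold higher number from compound 3 to compound 4 (0.78 log units; beyond the scatter), the widest step so far among the arms with a carbon-only ring, yet it keeps a lead over pyridin-3-yl, with a 2.7-fold lower number from compound 1 to compound 4 (0.43 log units; beyond the scatter), so all three such arms remain ahead of the arm with a ring nitrogen. Nothing measured alongside these numbers accounts for the order of the four arms.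

The compounds shown leave open whether the rise from 3-chlorophenyl to 4-chloro-3-methylphenyl follows the new place of the chlorine, the added methyl, or both together. Also open, on these data alone, is how this position would respond to an ethoxy group, a primary amine or a carboxylic acid on the phenyl ring, and whether any of these would match 3-methoxyphenyl.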